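Replacing ethoxy with morpholin-4-yl on a carbonyl carbon

The source may report more compounds than this note shows. Statements on the series, on what has been measured and on what is new or still open speak of the compounds shown alone.

Compound 1 `CNC(=O)/C=C/c1ccncc1-c1ccc2cc[nH]c2c1`: 10400 nM
Compound 2 `CCOC(=O)/C=C/c1ccncc1-c1ccc2cc[nH]c2c1`: 2140 nM
Compound 3 `O=C(/C=C/c1ccncc1-c1ccc2cc[nH]c2c1)N1CCOCC1`: not yet measured

Within the data shown here, in a functional assay on HCT-116 cells (Homo sapiens) for inhibition, read by MTT assay, with a stated time of 72 h (a higher number here means a weaker inhibitor of growth, a lower number a stronger inhibitor of growth), compound 2 holds the lower of the two numbers so far, at 2140 nM. The change that follows is morpholin-4-yl in place of ethoxy on a carbonyl carbon, with morpholin-4-yl in place of ethoxy on a carbonyl carbon, and it gives compound 3. Among the measured compounds shown here, one measured step bears on this change: a 4.9-fold lower number from compound 1 to compound 2 (0.69 log units; beyond the scatter), a modest step, with ethoxy in place of methylamino on a carbonyl carbon. Compound 3 is an amide, as compound 1 is, although no amide bearing a ring has been measured, and a single step is thin support. A move back towards the number of compound 1 is therefore expected, and the expected step is a 2.8-fold higher number from compound 2 to compound 3 (0.45 log units; beyond the scatter). Compound 3 is estimated at 6000 nM, with an expected range of 2500 nM to 15000 nM.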

Compound 3, concentration for 50% growth inhibition: > 30000 nM
Compound 3 ended at the assay's limit; the forecaster's own chance of this, stated with the estimate: 10%; middle value at least 5.0-fold (0.69 log units) from the limit.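

In this assay compound 3 gives a limit of the assay and not a number: the limit of > 30000 nM in this assay, at which 1 of the 3 values shown sits. The morpholin-4-yl group therefore gives an at least 14-fold higher number from compound 2 to compound 3 (1.14 log units; beyond the scatter), and set against the methylamino group it gives an at least 2.8-fold higher number from compound 1 to compound 3 (0.46 log units; beyond the scatter). Compound 1 and compound 3 are both amides, so the amide carbonyl alone does not fix the number, and the group on the carbonyl carbon can take growth inhibition out of the measurable range of this series.

The compounds shown leave open whether this loss goes with the ring itself or with the oxygen in it, a question on which a piperidin-1-yl or a dimethylamino group on the same carbonyl carbon would bear. From the compounds shown here alone, how far compound 3 lies beyond the limit also stays unknown.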